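Adding one methyl to the lowest-number compound

The compounds below may be only part of what the source reports. "The series", "measured", "known", "first", "only" and "open" are said of these compounds alone.

- Compound 1 `COC(=O)c1sc2c(C)cccc2c1Nc1cc(OC)c(OC)c(OC)c1` gives 4550 nM
- Compound 2 `CCOC(=O)c1sc2cccc(C)c2c1Nc1cc(OC)c(OC)c(OC)c1` gives 4150 nM
- Compound 3 `COC(=O)c1sc2ccccc2c1Nc1cc(OC)c(OC)c(OC)c1` gives 795 nM

All three were tested in a functional assay on MCF7 cells (Homo sapiens) for cytotoxicity, read by MTT assay, with a stated time of 72 h (a lower number here means a stronger inhibitor, a higher number a weaker inhibitor), and compound 3 has the lowest number, clearly apart from the other two. Compound 4 `COC(=O)c1sc2cccc(C)c2c1Nc1cc(OC)c(OC)c(OC)c1` is compound 3 with methyl in place of hydrogen on an aromatic carbon and nothing else changed.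

One measured step is closely related: a 5.7-fold lower number from compound 1 to compound 3 (0.76 log units; beyond the scatter), a modest change beyond the scatter, where a methyl on a different aromatic carbon gives way to hydrogen. Read in reverse, it suggests that adding a methyl may raise the number. Compound 2 carries its methyl on the same carbon as compound 4 but is an ethyl ester, not a methyl ester, so it differs from compound 3 in two places. Among the compounds with values here, compound 2 gives 4150 nM, which is higher than the value of compound 3, but no measured step isolates this methyl alone. A rise of similar size is therefore expected, though less firmly.

The expected change is a 4.0-fold higher number from compound 3 to compound 4 (0.60 log units; beyond the scatter), an estimated rise beyond the scatter. For compound 4 the estimated value is 3200 nM, with an expected range from 1200 nM to 7500 nM.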

Compound 4, half-maximal inhibitory concentration: 8190 nM
For compound 4 the middle estimate is 2.6-fold (0.41 log units) below the measured one; measured number outside the range, above it.
By their numbers in this assay, from the lowest: compound 3; then compounds 2, 1 and 4 (each within the scatter of the next).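

this assay shows a 10-fold higher number from compound 3 to compound 4 (1.01 log units; beyond the scatter) with the ester unchanged, so this single methyl on an aromatic carbon is now seen alone, and it brings a large loss of potency. Changing the ester in the presence of this methyl gives a 2.0-fold higher number from compound 2 to compound 4 (0.30 log units; within the scatter) and so cannot be told apart from scatter, which points to the methyl, not the ester, as the change that matters between these compounds. No measurement at hand explains why this one methyl has so large an effect.

On these data alone, it remains open whether a different group on this carbon, such as a fluorine, a methoxy or an amine, would behave like methyl or like hydrogen. As far as these compounds go, it also remains open whether a longer chain on the ester would stay as silent as the ethyl ester does here.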